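A few compounds are considered here, and "the series" means these few. Any claim that something is new, unique, unknown or untested is made for them only; others in the source may bear on it.

Three compounds have been measured in a functional assay on the whole organism (strain albino) for inhibition, with Rattus norvegicus as the target, read by paw edema, with stated times of 1 h and 2 h, at a dose of 20 mmol/kg by the intraperitoneal route; a lower number here means less inhibition, a higher number more inhibition at the dose given (going by the name of the read-out):

Compound 1, `COc1ccc(N/C=N/C2=C(C#N)C3C(N4CCCC4)CCCCN3C(=O)N2c2ccccc2)cc1`, gives 37.2%.
Compound 2, `N#CC1=C(/N=C/c2ccccc2)N(c2ccccc2)C(=O)N2CCCCC(N3CCCC3)C12`, gives 75.9%.
Compound 3, `N#CC1=C(/N=C/Nc2ccccc2)N(c2ccccc2)C(=O)N2CCCCC(N3CCCC3)C12`, gives 47.5%.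

Compound 1 stands lowest of the three. Its nearest neighbour is compound 3, reached by a number 10.3 percentage points higher from compound 1 to compound 3 (beyond the scatter), a change of hydrogen in place of methoxy on an aromatic carbon. The furthest is compound 2, reached by a number 38.7 percentage points higher from compound 1 to compound 2 (beyond the scatter), where phenyl stands in place of (4-methoxyphenyl)amino on the carbon with a double bond to nitrogen. Between the two higher compounds, a number 28.4 percentage points lower from compound 2 to compound 3 (beyond the scatter), with anilino in place of phenyl on that same carbon.

Compound 4, `N#CC1=C(NCC(=O)N2CCCCC2)N(c2ccccc2)C(=O)N2CCCCC(N3CCCC3)C12`, differs from compound 1 by a group of 10 heavy atoms (7 carbon, 2 nitrogen, 1 oxygen; one six-membered non-aromatic ring with 1 hetero atom) in place of a group of 11 heavy atoms (8 carbon, 2 nitrogen, 1 oxygen; one six-membered aromatic ring of carbon only), on a double-bonded ring carbon. For the measured compounds named here, no measured step reproduces this exchange: the two steps that leave compound 1 both alter or strip the aryl part of the group, and both run upward, one large and one modest, while the entering (((piperidin-1-yl)carbonyl)methyl)amino group has no measured counterpart among compounds 2 and 3. The step is therefore expected to be a modest rise, a number 12.8 percentage points higher from compound 1 to compound 4 (beyond the scatter), with wide uncertainty. Compound 4 is estimated at 50%, in a range from 30% to 70%.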

Compound 4, a percentage reported as inhibition, in the whole organism at one dose (the size of the read-out at that dose, not a potency): 46.1%
Compound 4: middle estimate off by 3.9 percentage points, on the high side; measured number inside the range.
By their numbers in this assay, from the lowest: compounds 1, 4 and 3 (each within the scatter of the next, the first and the last beyond it); then compound 2.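

Placed on the double-bonded ring carbon, the (((piperidin-1-yl)carbonyl)methyl)amino group carries no aromatic ring and no carbon with a double bond to nitrogen, yet in this assay it does not separate from the aryl-bearing groups, with a number 8.9 percentage points higher from compound 1 to compound 4 (within the scatter) and a number 1.4 percentage points lower from compound 3 to compound 4 (within the scatter) as the two comparisons. Inhibition at the level of compounds 1 and 3 therefore does not depend on an aromatic ring in this group, while a number 29.8 percentage points lower from compound 2 to compound 4 (beyond the scatter) leaves compound 2, with its phenyl on the carbon with a double bond to nitrogen, alone at the top of the four. Nothing measured here accounts for these steps.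

The compounds shown leave open which part of the entering group matters, since a carboxylic acid or a dimethylamide in place of the piperidine amide would separate the piperidine ring from the linking chain. As far as these compounds go, it also remains open whether a saturated group such as cyclohexyl on the carbon with a double bond to nitrogen would match compound 2 or fall back to the level of the other three.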